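From cyclobutyl to morpholin-4-yl on an amide-type nitrogen

This account rests on a few compounds, and the source may have more. Where it says the series, first, only, none or still open, it means among the compounds named here.

In an ADME assay on MRC5 cells (Homo sapiens) for inhibition, with a stated time of 72 h (on this read-out higher numbers stand for an effect only at larger amounts of compound and lower numbers for an effect already at smaller amounts), compound 1 `COc1cccc(OC)c1C(=O)Nc1c[nH]nc1C(=O)N[C@H]1CC[C@H](OC)CC1` gives 31000 nM, and compound 2 `COc1cccc(OC)c1C(=O)Nc1c[nH]nc1C(=O)N[C@H]1CC[C@H](O)CC1` gives 34000 nM. Compound 3 `COc1cccc(OC)c1C(=O)Nc1c[nH]nc1C(=O)NC1CCC1` reads > 50000 nM, which is a limit of the assay and not a number. Compound 4 `COc1cccc(OC)c1C(=O)Nc1c[nH]nc1C(=O)NN1CCOCC1` carries morpholin-4-yl in place of cyclobutyl on an amide-type nitrogen. Two measured swaps at that same nitrogen bear on this change: an at least 1.6-fold higher number from compound 1 to compound 3 (0.20 log units; that floor lies within the scatter), and an at least 1.4-fold higher number from compound 2 to compound 3 (0.16 log units; that floor lies within the scatter), so no step beyond the scatter is expected in this assay. The estimated step is an at least 1.1-fold lower number from compound 3 to compound 4 (0.04 log units; that floor lies within the scatter). For compound 4 the expected value is 45000 nM, with an estimated range from 22000 nM to 80000 nM.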

Compound 4, half-maximal effective concentration: > 50000 nM
Compound 4: no number, only a limit; the forecaster's own chance of this, stated with the estimate: 60%; at least 1.1-fold (0.04 log units) between middle value and limit.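

In this assay compound 4 gives > 50000 nM, which is a limit of the assay and not a number. The step from cyclobutyl to morpholin-4-yl on the amide-type nitrogen therefore cannot be read, and compound 3 and compound 4 rest at the same limit: the limit of > 50000 nM in this assay, at which 2 of the 4 values shown sit. Against the cyclohexyl compounds there is an at least 1.4-fold higher number from compound 2 to compound 4 (0.16 log units; that floor lies within the scatter) and an at least 1.6-fold higher number from compound 1 to compound 4 (0.20 log units; that floor lies within the scatter), so morpholin-4-yl does not separate from either of those groups here. As far as these compounds go, what a piperidin-1-yl group or a chain ending in a carboxylic acid would give on this nitrogen stays open, as does whether any group there can bring the number clearly lower.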